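The compounds below may be only part of what the source reports. "The series", "measured", "known", "first", "only" and "open" are said of these compounds alone.

Compound 3 `CN(C)c1ccc(C2CC(c3ccc(-n4cncn4)cc3)=NN2C(=O)c2ccc(F)cc2)cc1` stands lowest of the three measured numbers: in a functional assay on HCC1806 cells (Homo sapiens) for inhibition, read by sulforhodamine B assay, tested at 10 uM (a lower number here means less inhibition, a higher number more inhibition at the concentration tested (going by the name of the read-out)), compound 3 gives 15.6%, while compound 1 `CN1CCN(c2ccc(C3=NNC(c4ccc(N(C)C)cc4)C3)cc2)CC1` gives 31.2% and compound 2 `CN1CCN(c2ccc(C3=NN(C(=O)c4ccc(F)cc4)C(c4ccc(N(C)C)cc4)C3)cc2)CC1` gives 31.8%. The step that placed (4-fluorophenyl)carbonyl on the ring amine nitrogen was small, a number 0.6 percentage points higher from compound 1 to compound 2 (within the scatter), whereas the exchange on the aromatic carbon was larger, a number 16.2 percentage points lower from compound 2 to compound 3 (beyond the scatter). Compound 4 `CN(C)c1ccc(C2CC(c3ccc(-n4cncn4)cc3)=NN2S(=O)(=O)c2ccc(Br)cc2)cc1` differs from compound 3 in one place: (4-bromophenyl)sulfonyl in place of (4-fluorophenyl)carbonyl on an amine nitrogen in a ring. Among the compounds with values here, only the first step touches the same nitrogen, and it stayed within the scatter; no measured pair exchanges a carbonyl for a sulfonyl. Compound 4 is therefore expected to show no step beyond the scatter, a number 0.4 percentage points higher from compound 3 to compound 4 (within the scatter), and is estimated at 16%, between 5% and 29%.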

Compound 4, a percentage reported as inhibition, at one concentration (the size of the read-out at that concentration, not a potency): 26.3%
Estimate against measurement, compound 4: 10.3 percentage points below, and the stated range covers the measured number.
By their numbers in this assay, from the lowest: compound 3; then compounds 4, 1 and 2 (each within the scatter of the next).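

On the amine nitrogen in a ring, placing (4-fluorophenyl)carbonyl in place of hydrogen left a number 0.6 percentage points higher from compound 1 to compound 2 (within the scatter), but in this assay the exchange for (4-bromophenyl)sulfonyl gave a number 10.7 percentage points higher from compound 3 to compound 4 (beyond the scatter) and so showed that the number can respond to what this nitrogen carries. This holds for the compounds bearing the 4-(1H-1,2,4-triazol-1-yl)phenyl group. No available evidence bears on the reason for this step. Going by these compounds, the exchange alters the sulfonyl and the bromine together, so their separate contributions remain open. Also open, on these data alone, is what a methylsulfonyl group would give on this nitrogen.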